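Swapping Fluoro for Trifluoromethoxy on an Aromatic Carbon

The source may report more compounds than this note shows. Statements on the series, on what has been measured and on what is new or still open speak of the compounds shown alone.

In a functional assay on NCI-H460 cells (Homo sapiens) for inhibition, read by MTT assay, with a stated time of 24 h, tested at 0.1 ug/mL (a higher number here means more inhibition of growth at the concentration tested, a lower number less inhibition of growth), compound 2 (`O=C(CCCCC(S)CCS)Nc1ccc(F)cc1`) gives 5.64%. For the measured compounds named here, the only other measured compound, compound 1 (`O=C(CCCCC1CCSS1)Nc1ccc(OC(F)(F)F)cc1`), gives 7.05%. These two numbers lie within the usual scatter of each other, so compound 2 cannot be ranked apart from compound 1.

The next molecule is compound 3 (`O=C(CCCCC(S)CCS)Nc1ccc(OC(F)(F)F)cc1`), which has trifluoromethoxy in place of fluoro on an aromatic carbon of compound 2: trifluoromethoxy in place of fluoro on an aromatic carbon. The new group sits para to a large group, and the rest of the molecule stays the same.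

Going by the values given here, no measured pair shows this change alone, so the expectation rests on indirect evidence. Compound 1 carries the same trifluoromethoxy group and differs from compound 3 elsewhere. In this assay, compound 1 gives 7.05%. That value suggests no step beyond the scatter. The expected result is a number 1.4 percentage points higher from compound 2 to compound 3 (within the scatter), a small rise that two data points can only loosely support. For compound 3, the estimated value is 7%, with an expected range from 2% to 15%.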

Compound 3, percent growth inhibition at one concentration: 17.3%
Estimate against measurement, compound 3: 10.3 percentage points below, and the stated range ends below it.
By their numbers in this assay, from the lowest: compounds 2 and 1 (each within the scatter of the next); then compound 3.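

In this assay, replacing fluoro with trifluoromethoxy on an aromatic carbon, para to a large group, gives a number 11.7 percentage points higher from compound 2 to compound 3 (beyond the scatter), so with the ring-free chain in place, the group at this position changes the result by more than the scatter. The chain matters as well: with trifluoromethoxy held constant, replacing the group containing a five-membered non-aromatic ring with 2 hetero atoms by the ring-free group of 5 heavy atoms gives a number 10.3 percentage points higher from compound 1 to compound 3 (beyond the scatter), so the higher number for compound 3 comes with this chain and this aromatic group together, and neither step alone shows what either change does in another setting. Nothing available explains why either step occurs.

The compounds shown leave open whether a chlorine atom, a methoxy group or a trifluoromethyl group at this position would give a similar number, and whether the rise depends on having the ring-free chain. They also leave open how the compounds compare at other concentrations, since each number here is a reading at a single concentration.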